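Phenoxy for benzyl on the shared core of compound 1

The source may report more compounds than this note shows. Statements on the series, on what has been measured and on what is new or still open speak of the compounds shown alone.

Compound 1 `CCc1ccccc1N(Cc1nnc(Cc2ccccc2)o1)S(=O)(=O)c1ccc(C)cc1` gives 1000 nM in an assay on CHO cells for displacement of a labelled ligand from prostaglandin E2 receptor EP1 subtype (Homo sapiens) (on this read-out lower numbers stand for stronger inhibition and higher numbers for weaker inhibition), the highest of the three numbers. Compound 2 `Cc1ccc(S(=O)(=O)N(Cc2nnc(Cc3cccc(F)c3)o2)c2cccc(Cl)c2C)cc1` gives 316 nM in this assay, and compound 3 `Cc1ccc(S(=O)(=O)N(Cc2nnc(Cc3cccc(Cl)c3)o2)c2cccc(Cl)c2C)cc1` gives 158 nM, so compound 1 stands measurably weaker than both. Within the data shown here, the one step between measured compounds, a 2.0-fold lower number from compound 2 to compound 3 (0.30 log units; within the scatter), exchanges one halogen for another and lies within the scatter. Compound 4 `CCc1ccccc1N(Cc1nnc(Oc2ccc(OC)cc2)o1)S(=O)(=O)c1ccc(C)cc1` differs from compound 1 by 4-methoxyphenoxy in place of benzyl on an aromatic carbon. Among the measured compounds shown here, no measured step touches that position or that kind of exchange; the numbers give no direction. No change beyond the scatter is therefore expected, no change at the digits printed from compound 1 to compound 4 (within the scatter). Compound 4 is estimated at 1000 nM, within a range from 250 nM to 4000 nM.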

Compound 4, half-maximal inhibitory concentration: < 1000 nM
Compound 4 gave a limit, no number; the forecaster's own chance of this, stated with the estimate: 20%; the middle value sits exactly at the limit.
By their numbers in this assay, from the lowest: compounds 3 and 2 (each within the scatter of the next); then compound 1.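

Compound 4 gives only a limit in this assay, not a number: < 1000 nM. Among these compounds, this is the first measured change on an aromatic carbon of a five-membered aromatic ring, and 4-methoxyphenoxy in place of benzyl gives a number no higher from compound 1 to compound 4 (the limit leaves the size open). The size of the step cannot be read, and how far compound 4 lies from the other compounds stays open: the limit of < 1000 nM in this assay, at which 1 of the 4 values shown sits.

From the compounds shown here alone, it also remains open how an amine or a carboxylic acid would read at this position. The same holds for phenoxy without its methoxy group.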